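The source may report more compounds than this note shows. Statements on the series, on what has been measured and on what is new or still open speak of the compounds shown alone.

Compound 1 `C[C@@H](NC(=S)NCc1ccccc1)c1nc2ccccc2[nH]1` is tested in a functional assay on MCF7 cells (Homo sapiens) for cytotoxicity, read by MTT assay (a lower number here means a stronger inhibitor, a higher number a weaker inhibitor), where compound 1 gives 14300 nM. Going by the values given here, of the two numbers measured in this assay it is the lower one; its only neighbour, compound 2 `CC(C)C[C@@H](NC(=S)NCc1ccccc1)c1nc2ccccc2[nH]1`, gives 18200 nM in this assay, and the step of a 1.3-fold higher number from compound 1 to compound 2 (0.10 log units; within the scatter) is too small to separate the two compounds. That single step concerns an isopropyl in place of hydrogen on a saturated chain carbon, two bonds along the chain from an amide-type nitrogen and an aromatic carbon; it says nothing about configuration.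

Compound 3 `C[C@H](NC(=S)NCc1ccccc1)c1nc2ccccc2[nH]1` differs from compound 1 as follows: the two compounds have the same atoms and bonds and differ only in configuration as drawn: 1 of 1 stereo elements differ; a stereocentre at a saturated chain carbon is drawn R in compound 1 and S in compound 3. Among the compounds with values here, no measured step bears on an inversion of this kind, so the account rests on compound 1 alone. The step of a 1.1-fold higher number from compound 1 to compound 3 (0.05 log units; within the scatter) is expected to stay within the scatter, with a wide margin for an effect of either sign. For compound 3 the expected value in this assay is 16000 nM, between 5000 nM and 50000 nM.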

Compound 3, half-maximal inhibitory concentration: 217000 nM
Beside the measured number, compound 3's estimate is 14-fold (1.13 log units) below it; measured number above the stated range.
By their numbers in this assay, from the lowest: compounds 1 and 2 (each within the scatter of the next); then compound 3.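

In this assay the step of a 15-fold higher number from compound 1 to compound 3 (1.18 log units; beyond the scatter) is large, and it far exceeds the earlier step of a 1.3-fold higher number from compound 1 to compound 2 (0.10 log units; within the scatter) which stayed within the scatter. The stereocentre at the saturated chain carbon is therefore a place where the number responds strongly to configuration, with R as drawn in compound 1 the lower of the two, something the earlier step could not show. The gap can be laid to configuration alone, because nothing else separates the pair: the fact that compounds 1 and 3 differ only in the configuration as drawn

The compounds shown leave open whether the same inversion would weigh as heavily in compound 2, which carries the isopropyl. They also leave open how an amine or a carboxylic acid on that chain would fare in either configuration, and what underlies the preference for R.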